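From Thioester to Ketone on a Lipophilic Chain

This account rests on a few compounds, and the source may have more. Where it says the series, first, only, none or still open, it means among the compounds named here.

Compound 1 `COC(C)(C)CCCC(C)C/C=C/C(C)=C/C(=O)OC(C)(C)C` and compound 2 `C=CCSC(=O)/C=C(C)/C=C/CC(C)CCCC(C)(C)OC` have both been measured in a physicochemical assay for lipophilicity; a higher number here means a more lipophilic compound, a lower number a more polar compound: compound 1 gives 6.36, and compound 2 gives 6.77, the higher of the two numbers. Among the measured compounds shown here, the only measured step, a number 0.41 log units higher from compound 1 to compound 2 (beyond the scatter), changes the group on a carbonyl carbon. Compound 3 `CCC(C)C(=O)/C=C(C)/C=C/CC(C)CCCC(C)(C)OC` differs from compound 2 by sec-butyl in place of allylsulfanyl on a carbonyl carbon, at that same carbonyl carbon. For the measured compounds named here, no measured step swaps allylsulfanyl for sec-butyl, so the earlier step is only a loose guide. The change is expected to shift this assay only slightly, a number 0.22 log units lower from compound 2 to compound 3 (within the scatter). Compound 3 is therefore estimated at 6.55, within 6 to 7.1.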

Compound 3, partition coefficient: 6.02
The estimate for compound 3 lay 0.53 log units above the measured number; the range from low to high includes it.
By their numbers in this assay, from the lowest: compound 3; then compound 1; then compound 2.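

At this carbonyl carbon, sec-butyl gives the lowest number of the three in this assay: replacing allylsulfanyl gives a number 0.75 log units lower from compound 2 to compound 3 (beyond the scatter) and replacing tert-butoxy gives a number 0.34 log units lower from compound 1 to compound 3 (beyond the scatter). The group here can therefore move the number beyond the scatter, even between allylsulfanyl and sec-butyl, which have the same number of heavy atoms. Nothing available explains these shifts. On these data alone, whether a dimethylamino group or a hydroxyl group on this carbonyl carbon would give a lower number remains open. So does whether these swaps would have the same size on a shorter chain.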